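Replacing the Benzyloxy Arm of Compound 2 with an Amide

The source may report more compounds than this note shows. Statements on the series, on what has been measured and on what is new or still open speak of the compounds shown alone.

Measured in an ADME assay on HEK293 cells for agonist activity at Toll-like receptor 8 (Homo sapiens), read by a luciferase reporter, with a stated time of 6 h; on this read-out higher numbers stand for an effect only at larger amounts of compound and lower numbers for an effect already at smaller amounts:
compound 1 `COCCCNc1nc(N)nc2ccccc12` gives 0.01 uM;
compound 2 `CCCCNc1nc(N)nc2cccc(OCc3ccccc3)c12` gives 1.66 uM;
compound 3 `CCCCNc1nc(N)nc2cccc(OCc3ccccc3OC)c12` reaches only the limit > 25 uM.

Compound 2 stands highest of the two real numbers, far above compound 1. Compound 3 sits at the limit of this assay, as the limit of > 25 uM in this assay, at which 1 of the 3 values shown sits, shows. Compound 4 `CCCCNc1nc(N)nc2cccc(C(=O)N(C)C(C)C)c12` carries isopropyl(methyl)carbamoyl in place of benzyloxy on an aromatic carbon. Among the measured compounds shown here, the one step that bears on it, an at least 15-fold higher number from compound 2 to compound 3 (1.17 log units; beyond the scatter), also changed the group at this position and went upward. The new group is smaller than the one it replaces, so a step in this assay of roughly a 1.2-fold higher number from compound 2 to compound 4 (0.08 log units; within the scatter) is expected, though the direction is uncertain. Compound 4 is estimated at 2 uM, within 0.3 uM to 15 uM.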

Compound 4, minimum effective concentration: > 25 uM
Compound 4 gave a limit, no number; the forecaster's own chance of this, stated with the estimate: 15%; at least 12-fold (1.09 log units) between middle value and limit.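

Swapping the benzyloxy arm for isopropyl(methyl)carbamoyl gives an at least 15-fold higher number from compound 2 to compound 4 (1.17 log units; beyond the scatter) in this assay. The rise seen earlier with an added methoxy is therefore not special to that group: a replacement with no ring at all also raises the number at this position. Compound 4 reaches only a limit, not a number: the limit of > 25 uM in this assay, at which 2 of the 4 values shown sit.

Going by these compounds, how far compound 3 and compound 4 lie past that limit stays open. So does whether a simple amine or a carboxylic acid on this aromatic carbon would bring the number back down.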